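A few compounds are considered here, and "the series" means these few. Any claim that something is new, unique, unknown or untested is made for them only; others in the source may bear on it.

Measured compounds:
- compound 1, `Cc1ccc(NC(=S)NC(=O)c2ccc(OCc3ccccc3)cc2)cc1-c1nc2ccccc2[nH]1` — in a functional assay on HT-29 cells (Homo sapiens) for inhibition, read by MTT assay, with a stated time of 48 h (a lower number here means a stronger inhibitor, a higher number a weaker inhibitor), compound 1 gives 28800 nM
- compound 2, `Cc1ccc(NC(=S)NC(=O)c2ccc(OCc3cccc(Cl)c3)cc2)cc1-c1nc2ccccc2[nH]1` — in this assay compound 2 gives 35300 nM

Only these two numbers are known. Compound 2 stands beside compound 1 rather than apart from it: the step of a 1.2-fold higher number from compound 1 to compound 2 (0.09 log units; within the scatter) is too small to count as a real difference. The next compound, compound 3 with structure `Cc1ccc(NC(=S)NC(=O)c2ccc(OCc3ccc(C(F)(F)F)cc3)cc2)cc1-c1nc2ccccc2[nH]1`, differs from compound 2 in the change (4-(trifluoromethyl)phenyl in place of 3-chlorophenyl on a saturated chain carbon bound to an oxygen on an aromatic ring). Among the compounds with values here, the one step that speaks to this is the move from compound 1 to compound 2, which also altered the same ring, and it gave a 1.2-fold higher number from compound 1 to compound 2 (0.09 log units; within the scatter), a change within the scatter. On that basis the new swap is expected to leave this assay roughly unchanged, with no step beyond the scatter in either direction, so the estimated step is a 1.1-fold lower number from compound 2 to compound 3 (0.03 log units; within the scatter). Compound 3 is therefore expected to give about 33000 nM, most likely between 15000 nM and 75000 nM.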

Compound 3, half-maximal inhibitory concentration: 17600 nM
The estimate for compound 3 lay 1.9-fold (0.27 log units) above the measured number; the measured number falls inside the stated range.
By their numbers in this assay, from the lowest: compounds 3, 1 and 2 (each within the scatter of the next).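

In this assay, the swap of 3-chlorophenyl for 4-(trifluoromethyl)phenyl gives a 2.0-fold lower number from compound 2 to compound 3 (0.30 log units; within the scatter) and adding trifluoromethyl to the unsubstituted ring gives a 1.6-fold lower number from compound 1 to compound 3 (0.21 log units; within the scatter) as the second step on this ring. So far, then, this ring has taken either a chloro or a trifluoromethyl group with no step beyond the scatter, although the swap from compound 2 to compound 3 alters both the group and its place on the ring. Nothing available bears on why these steps are this small.

On these data alone, whether an amine or a carboxylic acid on this ring would give a step beyond the scatter remains open. So does the effect of a longer chain in place of the benzyl link to the oxygen.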